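The source may report more compounds than this note shows. Statements on the series, on what has been measured and on what is new or still open speak of the compounds shown alone.

Going by the values given here, compound 2 `O=C(Nc1cc(C(F)(F)F)ccc1NC1CCCCC1)c1ccncc1` stands at the higher of the two numbers so far measured in a functional assay on NALM-6 cells (Homo sapiens) for cytotoxicity, read by MTT assay, with a stated time of 48 h; on this read-out higher numbers stand for weaker inhibition and lower numbers for stronger inhibition: in this assay compound 2 gives 59000 nM, while compound 1 `O=C(Nc1cc(C(F)(F)F)ccc1Nc1ccc(Br)cc1)c1ccncc1` gives 51900 nM, and the gap between them is a 1.1-fold higher number from compound 1 to compound 2 (0.06 log units; within the scatter). Compound 3 `O=C(Nc1cc(C(F)(F)F)ccc1NC1CCCCC1)c1ccccc1` was reported in this assay only as "not active" (no number reported), with no number attached. Compound 4 `CCN(CC)c1ccc(C(F)(F)F)cc1NC(=O)c1ccncc1` is reached from compound 2 by diethylamino in place of cyclohexylamino on an aromatic carbon. Among the compounds with values here, only one measured step bears on this change: a 1.1-fold higher number from compound 1 to compound 2 (0.06 log units; within the scatter), which swapped the group at the same nitrogen-bearing position and left the number within the scatter. With nothing else to go on, no step beyond the scatter is expected in this assay , and the outcome of compound 3 , "not active" (no number reported), shows that a report without a number is also possible here. Compound 4 is therefore expected to give about 60000 nM in this assay , somewhere between 25000 nM and 150000 nM. That expectation corresponds to a step of a 1.0-fold higher number from compound 2 to compound 4 (0.01 log units; within the scatter).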

Compound 4, half-maximal inhibitory concentration: 63600 nM
The estimate for compound 4 lay 1.1-fold (0.03 log units) below the measured number; the range from low to high includes it.
By their numbers in this assay, from the lowest: compounds 1, 2 and 4 (each within the scatter of the next).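

In this assay, the change gives a 1.1-fold higher number from compound 2 to compound 4 (0.03 log units; within the scatter), so replacing cyclohexylamino with diethylamino, which removes the ring and the one hydrogen-bond donor counted for cyclohexylamino, leaves the number within the scatter. The other new comparison gives a 1.2-fold higher number from compound 1 to compound 4 (0.09 log units; within the scatter), also within the scatter, so the (4-bromophenyl)amino, cyclohexylamino and diethylamino compounds cannot be told apart at this position in this assay. No measurement is available to explain this lack of separation.

From the compounds shown here alone, it remains open whether any group at this position can move the number beyond the scatter. A plain amino group, a morpholine or a longer chain such as dipropylamino could test this, as could a carboxylic acid carried on the chain.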